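The source may hold more compounds than are shown below. What is called first, only, known or untested is meant among the compounds shown, and "the series" means these compounds.

Two members of the series have been measured in an assay for inhibition of 17-beta-hydroxysteroid dehydrogenase type 2 (Homo sapiens), read by HPLC, with a stated time of 10 min, tested at 1 uM; a lower number here means less inhibition, a higher number more inhibition at the concentration tested (going by the name of the read-out). Compound 1 `Cc1ccc2nc(C(=O)c3ccc(F)c(O)c3)ccc2c1` gives 78%. Compound 2 `CN(c1ccc(F)c(O)c1)c1cccc(-c2cccc(O)c2F)n1` gives 100%, the higher of the two numbers, and compound 1, the nearest, stands at a distance beyond the usual scatter. The next member, compound 3 `Oc1cc(Nc2cccc(-c3cccc(O)c3F)n2)ccc1F`, is not yet measured. Its difference from compound 2 is the following.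

hydrogen in place of methyl on a nitrogen on an aromatic ring

Among the measured compounds shown here, no measured pair shows this change, so the expected step is small, a number 7 percentage points lower from compound 2 to compound 3 (within the scatter), a slight fall or none beyond the scatter. Compound 3 is therefore estimated at 93%, between 72% and 100%.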

Compound 3, a percentage reported as inhibition, at one concentration (the size of the read-out at that concentration, not a potency) in the 17-beta-hydroxysteroid dehydrogenase type 2 assay: 82%
Estimate against measurement, compound 3: 11 percentage points above; the range from low to high includes it.
By their numbers in the 17-beta-hydroxysteroid dehydrogenase type 2 assay, from the lowest: compounds 1 and 3 (each within the scatter of the next); then compound 2.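

Among the compounds shown here, in the 17-beta-hydroxysteroid dehydrogenase type 2 assay hydrogen in place of methyl on this nitrogen gives a number 18 percentage points lower from compound 2 to compound 3 (beyond the scatter), the first step that changes one place only, so this position responds to the change. In the 17-beta-hydroxysteroid dehydrogenase type 2 assay compound 3, with the hydrogen, still gives 82%, so methyl is not required for inhibition at the concentration tested. In a physicochemical assay for solubility, in phosphate buffer, with a stated time of 24 h, at pH 7.4, tested at 200 uM (a higher number here means a more soluble compound, a lower number a less soluble compound), compound 2 gives > 200000 nM, which is a limit of the assay. In the physicochemical assay compound 3 gives > 200000 nM, which is also a limit of the assay. In the physicochemical assay the step cannot be read: the limit of > 200000 nM in the physicochemical assay, at which 2 of the 2 values shown sit.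

On these data alone, whether ethyl or a longer chain on this nitrogen keeps, raises or lowers the inhibition in the 17-beta-hydroxysteroid dehydrogenase type 2 assay stays open.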